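Swapping the triazole substituent: from chlorobenzyl to cyclobutyl

The source may report more compounds than this note shows. Statements on the series, on what has been measured and on what is new or still open speak of the compounds shown alone.

Measured compounds:
compound 1 `COc1ccc([C@@H]2CC(=O)c3c(O)cc(OCc4cn(Cc5ccc(Cl)cc5)nn4)cc3O2)cc1O`: 17800 nM
compound 2 `COc1ccc([C@@H]2C/C(=N\O)c3c(O)cc(OCc4cn(-c5ccccc5)nn4)cc3O2)cc1O`: 6130 nM
compound 3 `COc1ccc([C@@H]2CC(=O)c3c(O)cc(OCc4cn(Cc5cccc(C#N)c5)nn4)cc3O2)cc1O`: 18000 nM

In a functional assay on RAW264.7 cells (Mus musculus) for inhibition, read by Griess assay, with stated times of 2 h and 24 h (on this read-out higher numbers stand for weaker inhibition and lower numbers for stronger inhibition), compound 1 gives the second highest of the three numbers. Compound 3 sits closest to it, and the step of a 1.0-fold higher number from compound 1 to compound 3 (0.00 log units; within the scatter) shows that exchanging one benzyl group for another on the triazole nitrogen left the read-out unchanged. Compound 2 gives the lowest number, but it differs from compound 1 in two places, so its value alone says nothing about the nitrogen substituent.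

The unmeasured compound 4 `COc1ccc([C@@H]2CC(=O)c3c(O)cc(OCc4cn(C5CCC5)nn4)cc3O2)cc1O` differs from compound 1 as follows: cyclobutyl in place of 4-chlorobenzyl on an aromatic nitrogen. Going by the values given here, the only step that bears on this position is a 1.0-fold higher number from compound 1 to compound 3 (0.00 log units; within the scatter), and it was flat, so compound 4 is expected to give a number close to compound 1, with a step of a 1.1-fold higher number from compound 1 to compound 4 (0.05 log units; within the scatter) that stays within the scatter. The estimate for compound 4 is 20000 nM, ranging from 7000 nM to 55000 nM.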

Compound 4, half-maximal inhibitory concentration: 15300 nM
The estimate for compound 4 lay 1.3-fold (0.12 log units) above the measured number; low and high end bracket the measured number.
By their numbers in this assay, from the lowest: compound 2; then compounds 4, 1 and 3 (each within the scatter of the next).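

On the aromatic nitrogen, the benzene ring of the substituent proves unnecessary for the read-out in this assay: cyclobutyl, with 4 heavy atoms in place of 8, gives a 1.2-fold lower number from compound 1 to compound 4 (0.07 log units; within the scatter), and set against the 3-cyanobenzyl group it gives a 1.2-fold lower number from compound 3 to compound 4 (0.07 log units; within the scatter). The position thus accepts a small non-aromatic ring as readily as either substituted benzyl group. Nothing available explains this flatness. As far as these compounds go, whether an amine or a carboxylic acid on this substituent would move the number remains open, as does whether cyclobutyl behaves the same way on the core of compound 2.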